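Replacing the Trifluoromethylphenyl Group with Difluorophenyl: Solubility Outlook

A few compounds are considered here, and "the series" means these few. Any claim that something is new, unique, unknown or untested is made for them only; others in the source may bear on it.

Measured so far in a physicochemical assay for solubility, using the shake flask method, measured as kinetic solubility, with a stated time of 20 h, at pH 2; on this read-out lower numbers stand for lower solubility and higher numbers for higher solubility:
- Compound 1 `Fc1ccc(-c2nc3cnc(Nc4ccccn4)cc3[nH]2)cc1F` gives 125000 nM.
- Compound 2 `Fc1cnc(Nc2cc3[nH]c(-c4cccc(C(F)(F)F)c4)nc3cn2)c(F)c1` gives < 5000 nM, which is a limit of the assay and not a number.
- Compound 3 `FC(F)(F)c1ccc(Nc2cc3[nH]c(-c4cccc(C(F)(F)F)c4)nc3cn2)nc1` gives < 5000 nM, again a limit of the assay rather than a number.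

Compound 3 therefore stands at the lower edge of what this assay can report, and it shares that position with compound 2 (the limit of < 5000 nM in this assay, at which 2 of the 3 values shown sit). Within the data shown here, the only single-point step among the measured compounds runs a step that the two limits leave unreadable from compound 2 to compound 3. Both ends of that step are limits, so its size cannot be read.

Compound 4 `Fc1ccc(-c2nc3cnc(Nc4ccc(C(F)(F)F)cn4)cc3[nH]2)cc1F` is the next compound. It differs from compound 3 in one place: 3,4-difluorophenyl in place of 3-(trifluoromethyl)phenyl on an aromatic carbon. Among the measured compounds shown here, compound 1 carries the same 3,4-difluorophenyl group and gives a much higher reading, but compound 1 also differs from compound 4 in the group on the nitrogen, so no measured step describes this change alone; the two values of compound 1 and compound 3 simply show the spread seen so far.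

The expectation for compound 4 in this assay is a modest rise, an at least 2.0-fold higher number from compound 3 to compound 4 (0.30 log units; that floor lies within the scatter), with a fair chance that only a limit is reported again. The estimate for compound 4 is 10000 nM, within a range from 3000 nM to 40000 nM.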

Compound 4, solubility: 6000 nM
Compound 4: the middle estimate sits 1.7-fold (0.22 log units) above what was measured; measured number inside the range.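

In this assay, 3,4-difluorophenyl in place of 3-(trifluoromethyl)phenyl on an aromatic carbon gives a readable number in compound 4, and the change is an at least 1.2-fold higher number from compound 3 to compound 4 (0.07 log units; that floor lies within the scatter). Compound 3 gives only a limit, so that step is a floor and not a true size: the limit of < 5000 nM in this assay, at which 2 of the 4 values shown sit.

Among these compounds, with the 3,4-difluorophenyl group held the same, trifluoromethyl in place of hydrogen on an aromatic carbon gives a 21-fold lower number from compound 1 to compound 4 (1.32 log units; beyond the scatter), which is the first large step in this set that can be read in full, and it shows that the group on the nitrogen can also move this number a long way.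

The compounds shown leave open how far the swap to 3,4-difluorophenyl moves the number on its own, since the only partner for this step ends in a limit and compound 1 has no partner carrying 3-(trifluoromethyl)phenyl. They also leave open how an amine or a carboxylic acid in place of the trifluoromethyl on the group on the nitrogen would read in this assay.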